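Aryl swap on compound 2 in the tetrazolylacetamide series

A few compounds are considered here, and "the series" means these few. Any claim that something is new, unique, unknown or untested is made for them only; others in the source may bear on it.

Measured compounds:
compound 1 `Cc1cc(NC(=O)Cn2nnc(-c3ccccc3)n2)n(C2CCCC2)n1` gives in an assay on HEK293 cells for activation of Kir3.1/Kir3.2 (Homo sapiens), read by thallium flux (a higher number here means a larger maximal response, a lower number a smaller maximal response), 105%
compound 2 `Cc1cc(NC(=O)Cn2nnc(-c3ccccn3)n2)n(C2CCCCC2)n1` gives in this assay 81%

Compound 2 stands at the lower of the two values, with compound 1 sitting a gap beyond the usual scatter above it. Compound 1 and compound 2 differ in two places, so their values alone do not give a single-change step. Compound 3 `Cc1ccc(-c2nnn(CC(=O)Nc3cc(C)nn3C3CCCCC3)n2)cc1` is not yet measured; the change from compound 2 is 4-methylphenyl in place of pyridin-2-yl on an aromatic carbon. Among the compounds with values here, as no single-change pair exists among the measured compounds, the step size is uncertain, and only a modest rise is expected in this assay: a number 12 percentage points higher from compound 2 to compound 3 (beyond the scatter). Compound 3 is estimated at 93%, range 72% to 114%.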

Compound 3, largest response reached (Emax), in percent of the reference or control that the assay uses: 86%
Compound 3: the middle estimate sits 7 percentage points above what was measured; measured number inside the range.
By their numbers in this assay, from the lowest: compounds 2 and 3 (each within the scatter of the next); then compound 1.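

Within the data shown here, at the aromatic carbon of the five-membered aromatic ring with 4 nitrogen, 4-methylphenyl in place of pyridin-2-yl gives the first single-change step in this assay, which reads a number 5 percentage points higher from compound 2 to compound 3 (within the scatter) for the maximal response. This position therefore takes a carbon-only aromatic ring as well as one with a ring nitrogen, with no change in response beyond the scatter. The swap alters the ring nitrogen and the methyl together, so their separate contributions remain unresolved. Going by these compounds, whether an amine or a carboxylic acid in place of the methyl would hold this response remains open. No available measurement accounts for this result.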